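The source may hold more compounds than are shown below. What is called first, only, known or untested is meant among the compounds shown, and "the series" means these compounds.

Compound 2, `CS(=O)(=O)c1cnc(O[C@H]2CC[C@H](OC3CCN(CC4(C(F)(F)F)CCC4)CC3)CC2)cn1`, is the lower of the two numbers in hand: in a functional assay on isolated protein for agonist activity at Glucose-dependent insulinotropic receptor (Rattus norvegicus), read by HTRF and cAMP accumulation (on this read-out higher numbers stand for larger maximal responses and lower numbers for smaller maximal responses), compound 2 gives 99%, while compound 1, `C[C@@H](CF)OC(=O)N1CCC(O[C@H]2CC[C@H](Oc3cnc(S(C)(=O)=O)cn3)CC2)CC1`, gives 123%. Within the data shown here, the single measured step on the series, a number 24 percentage points lower from compound 1 to compound 2 (beyond the scatter), concerns the substituent carried on the amine nitrogen in a ring, which is the same part of the shared core that changes in the next compound. Compound 3, `CC(F)Cc1nc(CN2CCC(O[C@H]3CC[C@H](Oc4cnc(S(C)(=O)=O)cn4)CC3)CC2)no1`, differs from compound 2 by 5-(2-fluoropropyl)-1,2,4-oxadiazol-3-yl in place of 1-(trifluoromethyl)cyclobutyl on a saturated chain carbon bound to an amine nitrogen in a ring. Among the measured compounds shown here, only the step from compound 1 to compound 2 bears on this change, and it was of modest size and downward; no pair in hand exchanges one group at this place for another without also altering the rest, so the direction for compound 3 is open. A step of similar or smaller size than that of compound 1 to compound 2 is therefore expected, a number 9 percentage points higher from compound 2 to compound 3 (within the scatter), with no firm direction. For compound 3 the expected value is 108%, between 85% and 132%.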

Compound 3, largest response reached (Emax), in percent of the reference or control that the assay uses: 114%
Compound 3: the middle estimate sits 6 percentage points below what was measured, within the range that was stated.
By their numbers in this assay, from the lowest: compound 2; then compounds 3 and 1 (each within the scatter of the next).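

In this assay, among these compounds, the step of a number 15 percentage points higher from compound 2 to compound 3 (beyond the scatter) is the first to exchange one group for another on a saturated chain carbon bound to an amine nitrogen in a ring, and it shows that 5-(2-fluoropropyl)-1,2,4-oxadiazol-3-yl gives the larger maximal response of this pair. The step of a number 9 percentage points lower from compound 1 to compound 3 (within the scatter) shows that the two groups in this comparison, on an amine nitrogen in a ring, cannot be told apart on this read-out. No measurement in hand accounts for either step.

Going by these compounds, whether the 2-fluoropropyl chain or the five-membered aromatic ring carries the step from 1-(trifluoromethyl)cyclobutyl remains open. A plain propyl chain on the same ring would separate the two, and a longer chain would test how much size this place accepts.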